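Trimming a Methoxy Group from Compound 3

The compounds below may be only part of what the source reports. "The series", "measured", "known", "first", "only" and "open" are said of these compounds alone.

Compound 1, `COc1cc(-c2cc(/C=C/C(=O)c3ccc(N)cc3)[nH]n2)cc(OC)c1OC`: -81%
Compound 2, `COc1cc(-c2cc(/C=C/C(=O)c3ccc(Cl)c(Cl)c3)[nH]n2)cc(OC)c1OC`: -27%
Compound 3, `COc1ccc(C(=O)/C=C/c2cc(-c3cc(OC)c(OC)c(OC)c3)n[nH]2)cc1OC`: -99%

All three were tested in a functional assay on TK-10 cells (Homo sapiens) for cytotoxicity, read by sulforhodamine B assay, with a stated time of 48 h, tested at 100 uM; a lower number here means a stronger effect, a higher number a weaker effect of the compound at the concentration tested. Compound 3 gives the lowest number of the three: one of the steps leading to it is a number 18 percentage points lower from compound 1 to compound 3 (beyond the scatter), and the other is a number 72 percentage points lower from compound 2 to compound 3 (beyond the scatter), both beyond the scatter, so it stands as the strongest of the measured set.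

Compound 4, `COc1ccc(C(=O)/C=C/c2cc(-c3cc(OC)c(OC)c(OC)c3)n[nH]2)cc1`, has not been measured. It differs from compound 3 in one place: hydrogen in place of methoxy on an aromatic carbon.

The steps already seen all change the ring on the carbonyl carbon, the same ring that is altered here, but none of them removes a single methoxy group. The step from compound 1 to compound 3 was modest, a number 18 percentage points lower from compound 1 to compound 3 (beyond the scatter), while the step from compound 2 to compound 3 was large, a number 72 percentage points lower from compound 2 to compound 3 (beyond the scatter). Since compound 3 already sits near the floor of the scale, a modest weakening is the most that is expected, a step of a number 14 percentage points higher from compound 3 to compound 4 (beyond the scatter). Compound 4 is therefore estimated at -85%, within a range from -100% to -55%.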

Compound 4, a percentage reported as activity, at one concentration (the size of the read-out at that concentration, not a potency): -20%
Beside the measured number, compound 4's estimate is 65 percentage points below it, and the stated range ends below it.
By their numbers in this assay, from the lowest: compound 3; then compound 1; then compounds 2 and 4 (each within the scatter of the next).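

Removing one methoxy group, which turns 3,4-dimethoxyphenyl into 4-methoxyphenyl, is far from a small trim in this assay: the change is a number 79 percentage points higher from compound 3 to compound 4 (beyond the scatter) and shows that the effect depends heavily on this one spot, ortho to a methoxy group and meta to a large group. The earlier steps shown here exchanged substituents on this ring but never isolated a single methoxy group, and now the step of a number 7 percentage points higher from compound 2 to compound 4 (within the scatter) places 4-methoxyphenyl level with 3,4-dichlorophenyl, while the step of a number 61 percentage points higher from compound 1 to compound 4 (beyond the scatter) shows that methoxy in place of amino also gives a much weaker effect. Nothing measured here explains why this one group carries so much weight.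

The compounds shown leave open whether the oxygen alone or the whole methoxy group matters at this spot, and a hydroxy group or a longer ethoxy chain there would help to separate those two readings. They also leave open how much the remaining methoxy group contributes, which a plain phenyl ring or a 3-methoxyphenyl ring could test.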